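From methyl to trifluoromethyl on compound 1

This account rests on a few compounds, and the source may have more. Where it says the series, first, only, none or still open, it means among the compounds named here.

- compound 1 `Cc1cccc(-c2nc3cc(C)ccc3c(=O)[nH]2)c1` gives 21100 nM so far
- compound 2 `Cc1ccc2nc(-c3cccc(F)c3)[nH]c(=O)c2c1` gives > 50000 nM so far

Among the measured compounds shown here, in a functional assay on HCT-15 cells (Homo sapiens) for cytotoxicity, read by MTT assay, with a stated time of 2 days (a higher number here means a weaker inhibitor, a lower number a stronger inhibitor), compound 1 gives 21100 nM as the only true number so far. Compound 2 reads > 50000 nM here, and that is a limit of the assay and not a number. For the measured compounds named here, compound 1 is therefore the single firm reference point, and no two measured compounds differ in just one place.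

The next compound to be tested is compound 3 `Cc1ccc2c(=O)[nH]c(-c3cccc(C(F)(F)F)c3)nc2c1` which keeps the core of compound 1. The change is trifluoromethyl in place of methyl on an aromatic carbon in one place, with trifluoromethyl in place of methyl on an aromatic carbon, meta to a large group.

Going by the values given here, with no measured step to lean on, a modest move towards a higher number in this assay is expected, and a result within the usual scatter would be no surprise. The estimate amounts to an expected 1.3-fold higher number from compound 1 to compound 3 (0.12 log units; within the scatter) as a small step. For compound 3 the expected value is 28000 nM and the estimated range runs from 12000 nM to 60000 nM for now.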

Compound 3, half-maximal inhibitory concentration: > 50000 nM
Compound 3 was reported as a limit (the forecaster's own chance of this, stated with the estimate: 35%); middle value at least 1.7-fold (0.25 log units) from the limit.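

In this assay, among the compounds shown here, putting trifluoromethyl in place of methyl on this aromatic carbon gives an at least 2.3-fold higher number from compound 1 to compound 3 (0.37 log units; beyond the scatter), the first comparison between two compounds that differ in just one place. The step lies beyond the usual scatter, so this position is not indifferent to the change, and among these two compounds only the methyl group leaves a true number in the assay. The value of compound 3 is a limit and not a number, so the step gives only a minimum size and the full loss cannot be read: the limit of > 50000 nM in this assay, at which 2 of the 3 values shown sit.

How far compound 3 truly lies from compound 1 stays open, and the data give no reason for the loss, since a single swap cannot separate the possible explanations. Also open, as far as these compounds go, is whether another group on this carbon, such as an amine, a carboxylic acid or a longer chain like ethyl, would give a true number in this assay, and whether any of them would give a lower number than methyl does.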